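Compound 3 and its 1H-indol-6-yl counterpart, compound 4

A few compounds are considered here, and "the series" means these few. Any claim that something is new, unique, unknown or untested is made for them only; others in the source may bear on it.

Measured in a functional assay on MCF7 cells (Homo sapiens) for inhibition, read by CCK-8 assay, with a stated time of 48 h; a lower number here means a stronger inhibitor, a higher number a weaker inhibitor:
Compound 1 `COc1cc(-c2ccnc3cc(-c4ccc(F)cc4)nn23)cc(OC)c1OC`: 1280 nM
Compound 2 `COc1cc(-c2ccnc3cc(-c4cccc(C#N)c4)nn23)cc(OC)c1OC`: > 10000 nM
Compound 3 `COc1cc(-c2ccnc3cc(-c4ccccc4)nn23)cc(OC)c1OC`: 254 nM

Compound 3 (254 nM) holds the lowest of the two true numbers, and compound 1 (1280 nM) lies nearest to it. For compound 2, the reading (> 10000 nM) is a limit of the assay and not a number.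

Compound 4 `COc1cc(-c2ccnc3cc(-c4ccc5cc[nH]c5c4)nn23)cc(OC)c1OC` carries 1H-indol-6-yl in place of phenyl on an aromatic carbon of the shared core. Among the compounds with values here, two measured steps concern this same group: a 5.0-fold lower number from compound 1 to compound 3 (0.70 log units; beyond the scatter) and an at least 39-fold lower number from compound 2 to compound 3 (1.59 log units; beyond the scatter). In both, the unsubstituted phenyl of compound 3 gives the lower number. Within the data shown here, neither step introduces a fused ring, however, so they guide this change only loosely, and no step clearly beyond the scatter can be expected, in either direction. The step expected in this assay is a 1.7-fold lower number from compound 3 to compound 4 (0.23 log units; within the scatter), with considerable uncertainty. For compound 4 the estimated value is 150 nM, with an expected range from 15 nM to 2000 nM.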

Compound 4, half-maximal inhibitory concentration: 23 nM
Beside the measured number, compound 4's estimate is 6.5-fold (0.81 log units) above it; the range from low to high includes it.
By their numbers in this assay, from the lowest: compound 4; then compound 3; then compound 1. At a limit, above all of these: compound 2.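

The substituted phenyls of compound 1 and compound 2 both gave higher numbers than the unsubstituted phenyl of compound 3, which left open whether this position could take anything larger. In this assay, the 1H-indol-6-yl group, with its fused five-membered ring and its hydrogen-bond donor, goes the other way, with an 11-fold lower number from compound 3 to compound 4 (1.04 log units; beyond the scatter). Its distance from the other two groups is wider still, with a 56-fold lower number from compound 1 to compound 4 (1.75 log units; beyond the scatter) and an at least 430-fold lower number from compound 2 to compound 4 (2.63 log units; beyond the scatter), though the reading of compound 2 is a limit and not a number, so the second of these steps is only a bound: the limit of > 10000 nM in this assay, at which 1 of the 4 values shown sits.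

The compounds shown cannot separate the fused ring from the ring nitrogen and its hydrogen, as neither a 2-naphthyl nor a 1-methylindol-6-yl group stands among them. As far as these compounds go, how a 1H-indol-5-yl group would compare also remains open.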